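Removing the methyl from the hydroxyphenyl arm of compound 1

The source may hold more compounds than are shown below. What is called first, only, known or untested is meant among the compounds shown, and "the series" means these compounds.

Compound 1, `Cc1cccc(/C=N/c2ccc(OCc3ccccc3)cc2)c1O`: in a functional assay, with a stated time of 30 min (a higher number here means a weaker inhibitor, a lower number a stronger inhibitor), compound 1 gives > 200000 nM, which is a limit of the assay and not a number.
Compound 2, `Oc1ccc(O)c(/C=N/c2ccc(OCc3ccccc3)cc2)c1`: in this assay compound 2 gives 21300 nM.
Compound 3, `Cc1ccc(/C=N/c2ccc(OCc3ccccc3)cc2)c(O)c1`: in this assay compound 3 gives > 200000 nM, again a limit rather than a number.

Compound 1 thus stands at the limit of > 200000 nM in this assay, at which 2 of the 3 values shown sit, with no measurable number of its own. Going by the values given here, the one measured compound with a number, compound 2, is reached by an at least 9.3-fold lower number from compound 1 to compound 2 (0.97 log units; beyond the scatter), while moving the methyl gives a step that the two limits leave unreadable from compound 1 to compound 3, and going from the dihydroxy compound back to a methyl-bearing one gives an at least 9.3-fold higher number from compound 2 to compound 3 (0.97 log units; beyond the scatter).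

Compound 4, `Oc1ccccc1/C=N/c1ccc(OCc2ccccc2)cc1`, differs from compound 1 by hydrogen in place of methyl on an aromatic carbon. Among the compounds with values here, none of the measured steps removes a methyl outright; they either add a second hydroxy group or shift the methyl along the ring, and only the added hydroxy group brought a readable number. Because both methyl-bearing compounds sit at the limit of > 200000 nM in this assay, at which 2 of the 3 values shown sit, compound 4, which keeps a single hydroxy group, is expected to stay near that edge, so the expected step of a number no higher from compound 1 to compound 4 (the limit leaves the size open) is small or none beyond the scatter. Compound 4 is estimated at 200000 nM, in a range from 30000 nM to 1000000 nM.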

Compound 4, half-maximal inhibitory concentration: > 200000 nM
Compound 4: a limit, no number; the forecaster's own chance of this, stated with the estimate: 65%; the middle value lies on the limit itself.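

Taking the methyl away does not bring a readable number: compound 4, with its plain 2-hydroxyphenyl arm, gives only a limit of the assay and joins the methyl-bearing compound 1 and compound 3 at the same edge: the limit of > 200000 nM in this assay, at which 3 of the 4 values shown sit.

Going by these compounds alone, the one readable compound now has a direct partner without a methyl, and hydrogen in place of hydroxy gives an at least 9.3-fold higher number from compound 2 to compound 4 (0.97 log units; beyond the scatter), which ties the readable number in this small set to the second hydroxy group on the ring and not to the absence of a methyl. The steps from compound 1 and from compound 3 to compound 4 cannot be read, since both ends of each are limits, so any effect of the methyl on this arm remains hidden beyond the range of this assay.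

On these data alone, whether an amine or a methoxy group in place of that second hydroxy group would also give a readable number stays open. So does whether a methyl added to compound 2 would change its value.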